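A few compounds are considered here, and "the series" means these few. Any claim that something is new, unique, unknown or untested is made for them only; others in the source may bear on it.

Compound 1, `O=C(Nc1nc2ccccc2s1)c1cn(-c2ccccc2)nc1-c1ccc(Cl)cc1`, in a functional assay on U-87MG ATCC cells for cytotoxicity against U-87 MG (Homo sapiens), read by MTT assay, with a stated time of 72 h; on this read-out lower numbers stand for stronger inhibition and higher numbers for weaker inhibition: 11500 nM
Compound 2, `COc1ccc(-c2nn(-c3ccccc3)cc2C(=O)Nc2nc3ccccc3s2)cc1`, in this assay: 11500 nM
Compound 3, `COc1ccc(-c2nn(-c3ccccc3)cc2C(=O)Nc2nc3ccc(Cl)cc3s2)cc1`, in this assay: 8710 nM

The change from compound 1 to compound 2 is methoxy in place of chloro on an aromatic carbon, and the step it made was no change at the digits printed from compound 1 to compound 2 (within the scatter). The following step was a 1.3-fold lower number from compound 2 to compound 3 (0.12 log units; within the scatter). The difference between the core of compound 1 and the core of compound 3 is not broken down here.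

Compound 4, `COc1ccc(-c2nn(-c3ccccc3)cc2C(=O)Nc2nc3ccc(OC)cc3s2)cc1`, is still to be measured. It differs from compound 3 by methoxy in place of chloro on an aromatic carbon. This is the same kind of change as that between compound 1 and compound 2, yet its place is not the same: here the ring carrying it is part of a fused or bridged system of two rings, meta to a fused ring and para to a fused ring, whereas in the earlier pair the group sat para to a large group. Since the earlier step was no change at the digits printed from compound 1 to compound 2 (within the scatter), the expected step is a 1.1-fold higher number from compound 3 to compound 4 (0.06 log units; within the scatter). Compound 4 is therefore estimated at 10000 nM, likely between 5000 nM and 20000 nM.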

Compound 4, half-maximal inhibitory concentration: 5890 nM
Compound 4: middle estimate off by 1.7-fold (0.23 log units), on the high side; the range from low to high includes it.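

In this assay, the move from 6-chloro-1,3-benzothiazol-2-yl to 6-methoxy-1,3-benzothiazol-2-yl gave a 1.5-fold lower number from compound 3 to compound 4 (0.17 log units; within the scatter), and methoxy in place of hydrogen at the same place gave a 2.0-fold lower number from compound 2 to compound 4 (0.29 log units; within the scatter). Set beside the earlier pair, methoxy in place of chloro carried from one core to the other without a difference that can be told apart: the same change on two cores in this assay, no change at the digits printed (within the scatter) from compound 1 to compound 2 and a 1.5-fold lower number (0.17 log units; within the scatter) from compound 3 to compound 4, 1.5-fold (0.17 log units) apart, within the scatter of two such steps. Among the compounds shown here, this shows only that the two small steps agree at two different places, and it does not show that the change has a real effect on either core or that it would carry to a further core.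

The compounds shown leave open whether an amine or a carboxylic acid at this place would give a step beyond the scatter. As far as these compounds go, the same remains open for a longer chain in place of the methoxy.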